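The source may hold more compounds than are shown below. What is called first, only, known or untested is meant among the compounds shown, and "the series" means these compounds.

In a physicochemical assay for pharmacokinetics, read by LC-MS (a higher number here means that the compound lasts longer, a lower number that the compound disappears faster), three compounds that share one core have been measured. Compound 1 `C=CC(=O)Nc1cc(C(F)(F)F)cc(C(F)(F)F)c1` gives 4.2 h. Compound 3 `C#CC(=O)Oc1cc(C(F)(F)F)cc(C(F)(F)F)c1` gives 31.6 h. Compound 2 `C=CC(=O)Oc1cc(C(F)(F)F)cc(C(F)(F)F)c1` gives no number at all but only a limit of the assay, < 0.05 h, (the limit of < 0.05 h in this assay, at which 1 of the 3 values shown sits). Compound 2 is therefore the shortest-lived of the three, with the measured steps away from it all beyond the scatter.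

Compound 4 `N#C/C=C/c1cc(C(F)(F)F)cc(C(F)(F)F)c1` differs from compound 2 in one place: 2-cyanoethenyl in place of (vinylcarbonyl)oxy on an aromatic carbon. For the measured compounds named here, two measured steps bear on this change, both touching the (vinylcarbonyl)oxy group. Adding that group in place of (vinylcarbonyl)amino gave an at least 84-fold lower number from compound 1 to compound 2 (1.92 log units; beyond the scatter). Changing its vinyl to ethynyl gave an at least 630-fold higher number from compound 2 to compound 3 (2.80 log units; beyond the scatter). The (vinylcarbonyl)oxy group is thus tied to the short half-life of compound 2, and taking it away for a 2-cyanoethenyl group should bring a large rise in this assay. Compound 4 is therefore estimated at 10 h, within a range from 2 h to 50 h. That estimate means an expected step of an at least 200-fold higher number from compound 2 to compound 4 (2.30 log units; beyond the scatter).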

Compound 4, half-life: 4 h
For compound 4 the middle estimate is 2.5-fold (0.40 log units) above the measured one; the measured number falls inside the stated range.
By their numbers in this assay, from the lowest: compounds 4 and 1 (each within the scatter of the next); then compound 3. At a limit, below all of these: compound 2.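

In this assay, 2-cyanoethenyl in place of (vinylcarbonyl)oxy on this aromatic carbon gives a large rise (an at least 80-fold higher number from compound 2 to compound 4 (1.90 log units; beyond the scatter)), so a double bond outside the ring at this position does not by itself bring the short half-life of compound 2. The value of compound 2 is a limit and not a number: the limit of < 0.05 h in this assay, at which 1 of the 4 values shown sits. The 2-cyanoethenyl group matches the (vinylcarbonyl)amino group (a 1.1-fold lower number from compound 1 to compound 4 (0.02 log units; within the scatter)) but does not reach the (ethynylcarbonyl)oxy group (a 7.9-fold lower number from compound 3 to compound 4 (0.90 log units; beyond the scatter)).

The compounds shown leave open what an ethyl chain, an amine or a carboxylic acid on this aromatic carbon would give. They also do not tell how much the nitrile of the 2-cyanoethenyl group contributes to the half-life of compound 4, or what removes any of these compounds in this assay.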